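A few compounds are considered here, and "the series" means these few. Any claim that something is new, unique, unknown or untested is made for them only; others in the source may bear on it.

Compound 3 `CCc1sc(CCc2cc(OCC3(C)CC3)cc(NCc3cc(Cl)cc(NC(=O)OC(C)C)c3)n2)nc1C` stands second highest of the three numbers measured in an assay on cells for binding affinity to Neuropeptide Y receptor type 1 (Homo sapiens) (a higher number here means a weaker inhibitor, a lower number a stronger inhibitor), with compound 3 giving 17 nM. Compound 1 `CCCCCOc1cc(CCc2nc(C)c(CC)s2)nc(NCc2cc(Cl)cc(NC(=O)OC(C)C)c2)c1` gives 35 nM in this assay, and compound 2 `CC/C=C\CCOc1cc(CCc2nc(C)c(CC)s2)nc(NCc2cc(Cl)cc(NC(=O)OC(C)C)c2)c1` gives 4.7 nM. The measured steps are a 2.1-fold lower number from compound 1 to compound 3 (0.31 log units; beyond the scatter), a 3.6-fold higher number from compound 2 to compound 3 (0.56 log units; beyond the scatter) and a 7.4-fold lower number from compound 1 to compound 2 (0.87 log units; beyond the scatter).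

Compound 4 `CCc1sc(CCc2cc(OCCc3ccccc3)cc(NCc3cc(Cl)cc(NC(=O)OC(C)C)c3)n2)nc1C` differs from compound 3 in one place: benzyl in place of 1-methylcyclopropyl on a saturated chain carbon bound to an oxygen on an aromatic ring. Within the data shown here, the steps that bear on this change are those that also alter the group on a saturated chain carbon bound to an oxygen on an aromatic ring, namely a 2.1-fold lower number from compound 1 to compound 3 (0.31 log units; beyond the scatter) and a 3.6-fold higher number from compound 2 to compound 3 (0.56 log units; beyond the scatter), both modest and pointing in opposite directions. Among the measured compounds shown here, no measured compound carries a benzyl at this position, so the direction of the step for compound 4 is uncertain, and a modest step of either sign is the expected outcome in this assay. Compound 4 is therefore estimated at 20 nM, with a range from 6 nM to 70 nM, which corresponds to an expected step of a 1.2-fold higher number from compound 3 to compound 4 (0.07 log units; within the scatter).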

Compound 4, half-maximal inhibitory concentration: 30 nM
Estimate against measurement, compound 4: 1.5-fold (0.18 log units) below, and the stated range covers the measured number.
By their numbers in this assay, from the lowest: compound 2; then compounds 3, 4 and 1 (each within the scatter of the next, the first and the last beyond it).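

In this assay, replacing 1-methylcyclopropyl with benzyl gives a 1.8-fold higher number from compound 3 to compound 4 (0.25 log units; within the scatter) and phenyl in place of propyl gives a 1.2-fold lower number from compound 1 to compound 4 (0.07 log units; within the scatter), so this position accepts an aromatic ring without a step beyond the scatter from either of those two compounds. Phenyl in place of but-1-en-1-yl gives a 6.4-fold higher number from compound 2 to compound 4 (0.81 log units; beyond the scatter), which leaves compound 2 alone among these four compounds with a number beyond the scatter of all the others. Nothing available here accounts for these differences.

The compounds shown leave open whether the lower number of compound 2 belongs to its double bond or to the length of its chain, which a saturated hexyl group on this oxygen would test. They also leave open how a pyridine ring, an amine or a carboxylic acid would fare on this chain.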